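The source may report more compounds than this note shows. Statements on the series, on what has been measured and on what is new or still open speak of the compounds shown alone.

Measured so far in a functional assay on HepG2 cells (Homo sapiens) for antiproliferative activity, read by MTT assay; a lower number here means a stronger inhibitor, a higher number a weaker inhibitor:
- compound 1 `CCNC(=O)c1oc2nc(-c3ccccc3)cc(C(F)(F)F)c2c1N`: 42800 nM
- compound 2 `Nc1c(C(=O)N/N=C/c2ccc(Br)cc2)oc2nc(-c3cccs3)cc(C(F)(F)F)c12`: 6100 nM
- compound 3 `Nc1c(C(=O)NC2CCCC2)oc2nc(-c3ccccc3)cc(C(F)(F)F)c12`: 32400 nM

Compound 1 lies within the scatter of compound 3 and has a clearly higher number than compound 2, so it sits at the high end of this small set, level with compound 3.

The next compound is compound 4 `Nc1c(C(=O)N/N=C/c2ccccc2)oc2nc(-c3ccccc3)cc(C(F)(F)F)c12`, which keeps the core of compound 1 and changes only the amide substituent: a group of 8 heavy atoms (7 carbon, 1 nitrogen; one six-membered aromatic ring of carbon only) in place of a group of 2 heavy atoms (2 carbon; no ring), on an amide-type nitrogen.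

For the measured compounds named here, only one measured step changes this same substituent. Cyclopentyl in place of ethyl gives a 1.3-fold lower number from compound 1 to compound 3 (0.12 log units; within the scatter), so enlarging the group with a saturated ring leaves the value unmoved within the scatter. That step does not cover an aromatic ring or a double bond outside aromatic rings.

Going by the values given here, compound 2, at 6100 nM, is the only measured compound with a comparable group on the amide-type nitrogen. Among the compounds with values here, it differs from compound 4 elsewhere too, so it offers only indirect support, and no clean step isolates the change.

A moderate move towards a lower number in this assay is therefore expected, with a step within the scatter still possible. The expected step is a 3.1-fold lower number from compound 1 to compound 4 (0.49 log units; beyond the scatter). For compound 4 the estimated value is 14000 nM, with an expected range of 5000 nM to 40000 nM.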

Compound 4, half-maximal inhibitory concentration: 13100 nM
Compound 4: middle estimate off by 1.1-fold (0.03 log units), on the high side; low and high end bracket the measured number.
By their numbers in this assay, from the lowest: compound 2; then compound 4; then compounds 3 and 1 (each within the scatter of the next).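

In this assay, the substituent on the amide-type nitrogen now moves the value beyond the scatter: the new group, with its six-membered aromatic ring of carbon and its double bond outside aromatic rings, gives a 3.3-fold lower number from compound 1 to compound 4 (0.51 log units; beyond the scatter) against ethyl and a 2.5-fold lower number from compound 3 to compound 4 (0.39 log units; beyond the scatter) against cyclopentyl. Both steps are modest, but they contrast with a 1.3-fold lower number from compound 1 to compound 3 (0.12 log units; within the scatter), so among these three compounds a larger saturated ring leaves the value within the scatter, while this larger unsaturated group lowers it. Nothing available bears on why this group goes with the lower number.

The aromatic ring and the double bond enter together, so these compounds cannot show which of the two goes with the lower number, and a benzyl group on the amide-type nitrogen, or a longer chain ending in an amine, remains an open case. Going by these compounds, compound 2 differs from compound 4 in more than one place, so its steps cannot be read and the share of each of its changes stays unknown.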